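Taking the nitro group off compound 1

The source may report more compounds than this note shows. Statements on the series, on what has been measured and on what is new or still open speak of the compounds shown alone.

Among the measured compounds shown here, in a functional assay on 2008 cells (Homo sapiens) for cytotoxicity, read by MTT assay, with a stated time of 68 h (a higher number here means a weaker inhibitor, a lower number a stronger inhibitor), compound 1 `O=C(/C=C/c1cccc(OCc2ccccc2)c1)c1ccc([N+](=O)[O-])cc1` gives 49000 nM, the highest of the three numbers measured so far. Compound 2 `Cc1ccc(C(=O)/C=C/c2cccc(OCc3ccccc3)c2)cc1` gives 12900 nM, and compound 3 `O=C(/C=C/c1cccc(OCc2ccccc2)c1)c1ccccc1Br` gives 1200 nM. Compound 4 `O=C(/C=C/c1cccc(OCc2ccccc2)c1)c1ccccc1` has not yet been measured. It departs from compound 1 at a single place, hydrogen in place of nitro on an aromatic carbon, para to a large group: hydrogen in place of nitro on an aromatic carbon.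

The closest evidence is a 3.8-fold lower number from compound 1 to compound 2 (0.58 log units; beyond the scatter), a modest step in which methyl stands in place of nitro. A second step, a 41-fold lower number from compound 1 to compound 3 (1.61 log units; beyond the scatter), is large, but it swaps 4-nitrophenyl for 2-bromophenyl and so bears less directly on the loss of nitro. Both steps run toward lower numbers, so a modest drop of similar size is expected here, not a large one. The expected step is a 4.1-fold lower number from compound 1 to compound 4 (0.61 log units; beyond the scatter). For compound 4 the estimate is 12000 nM, with an expected range from 4000 nM to 32000 nM.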

Compound 4, half-maximal inhibitory concentration: 4900 nM
For compound 4 the middle estimate is 2.4-fold (0.39 log units) above the measured one, within the range that was stated.
By their numbers in this assay, from the lowest: compound 3; then compound 4; then compound 2; then compound 1.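

In this assay hydrogen in place of nitro brings a 10-fold lower number from compound 1 to compound 4 (1.00 log units; beyond the scatter) and hydrogen in place of methyl brings a 2.6-fold lower number from compound 2 to compound 4 (0.42 log units; beyond the scatter) so of the three groups at this place, para to a large group, hydrogen carries the lowest number and the methyl step covered only part of the distance from nitro. Hydrogen is still not the lowest of the series: hydrogen in place of bromo gives a 4.1-fold higher number from compound 3 to compound 4 (0.61 log units; beyond the scatter) and so compound 3 alone stands below compound 4. Nothing at hand explains why these steps take the sizes they do.

The compounds shown leave open whether an amine or a methoxy group at this place would fall below or above hydrogen. They also leave open whether bromo at this place would give a number like that of the 2-bromophenyl compound 3.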